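The source may report more compounds than this note shows. Statements on the series, on what has been measured and on what is new or still open speak of the compounds shown alone.

Working notes on the series. The shared core is kept throughout; the change under study is methoxy in place of methyl on an aromatic carbon. Compound 1 `CC[C@@H](CCn1cncn1)c1ccc(C)cc1` and compound 2 `CC[C@@H](CCn1cncn1)c1ccc(OC)cc1` form the measured pair for it. In an ADME assay on HEp-2 cells (Homo sapiens) for cytotoxicity, read by MTT assay, with a stated time of 3 days (a higher number here means that more compound is tolerated, a lower number that less compound is tolerated), compound 1 gives 69.9 ug/mL. In this assay compound 2 gives 146 ug/mL. The change methoxy in place of methyl on an aromatic carbon produced a 2.1-fold higher number from compound 1 to compound 2 (0.32 log units; beyond the scatter).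

Compound 3 `CCC[C@H](CCn1cncn1)c1ccc(C)cc1` carries a different core; how the core of compound 3 differs from the core of compound 1 is not broken down here. In this assay compound 3 gives 45.7 ug/mL; against compound 1 the gap is within the scatter, against compound 2 it is beyond it. Compound 4 `CCC[C@H](CCn1cncn1)c1ccc(OC)cc1` is not yet measured. It differs from compound 3 by methoxy in place of methyl on an aromatic carbon; the place is the same word for word as in the pair of compound 1 and compound 2, so this is the same change made on the other core.

Going by the values given here, for compound 4 the expected step is a 2.0-fold higher number from compound 3 to compound 4 (0.29 log units; within the scatter), set beside the earlier one because a 2.1-fold higher number from compound 1 to compound 2 (0.32 log units; beyond the scatter) is the only measurement of this change in hand; it rests on a single pair and on a second core whose difference from the first is not counted, so the range is kept wide. Compound 4 is expected at 90 ug/mL, between 50 ug/mL and 170 ug/mL.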

Compound 4, half-maximal cytotoxic concentration: 59.6 ug/mL
Estimate against measurement, compound 4: 1.5-fold (0.18 log units) above; the measured number falls inside the stated range.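

In this assay, methoxy in place of methyl on an aromatic carbon gives a 1.3-fold higher number from compound 3 to compound 4 (0.12 log units; within the scatter) on the core of compound 3, so on this core alone the step cannot be told apart from repeated measurement. Set beside the earlier step, the result gives no sign that the change behaves differently on the two cores: the same change on two cores in this assay, a 2.1-fold higher number (0.32 log units; beyond the scatter) from compound 1 to compound 2 and a 1.3-fold higher number (0.12 log units; within the scatter) from compound 3 to compound 4, 1.6-fold (0.20 log units) apart, within the scatter of two such steps

Going by these compounds alone, this agreement shows only that the two steps are compatible; with one pair on each core and one of the two steps within the scatter, it does not establish a step of fixed size that carries from core to core, and it says nothing about why the numbers move as they do.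

The compounds shown leave open whether the agreement extends to other groups on the same aromatic carbon, para to a large group, such as an ethoxy group, a chlorine atom, an amine or a carboxylic acid. They also leave open whether it holds on a core with a longer chain than that of compound 3, and whether this change behaves the same way in any read-out other than this assay for this series.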